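Swapping the acyl group on a thiourea: tolerability expectation

This account rests on a few compounds, and the source may have more. Where it says the series, first, only, none or still open, it means among the compounds named here.

Of the compounds shown here, two built on the same core have been tested in an ADME assay on Huh-7 cells (Homo sapiens) for cytotoxicity; a higher number here means that more compound is tolerated, a lower number that less compound is tolerated. Compound 1 `O=C(NC(=S)n1ccc2c(OCCCCCOc3ccc(Cl)cc3)cccc21)c1ccccc1` gives 29500 nM. Compound 2 `N#Cc1cccc(C(=O)NC(=S)N2CCc3c(OCCCCCOc4ccc(Cl)cc4)cccc32)c1` gives 9750 nM, which is the lower of the two numbers, and the gap to compound 1 lies beyond the usual scatter of repeated runs. The two compounds differ in more than one place, so nothing is said here about what each change alone contributes.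

Compound 3 `O=C(CCc1ccccc1)NC(=S)N1CCc2c(OCCCCCOc3ccc(Cl)cc3)cccc21` has not yet been measured in this assay. Its structure differs from compound 2 in a single place: phenethyl in place of 3-cyanophenyl on a carbonyl carbon. Nothing in the two measured values speaks directly to this change, so no step beyond the scatter is expected, and compound 3 is estimated to sit at 12000 nM, within a range from 5000 nM to 30000 nM. The expected move is a 1.2-fold higher number from compound 2 to compound 3 (0.09 log units; within the scatter), which is a modest one.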

Compound 3, half-maximal cytotoxic concentration: > 50000 nM
Compound 3 gave a limit, no number (the forecaster's own chance of this, stated with the estimate: 5%); middle value at least 4.1-fold (0.61 log units) away from the limit.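

Holding the rest of the molecule fixed, the group on the carbonyl carbon clearly matters in this assay: phenethyl in place of 3-cyanophenyl gives an at least 5.1-fold higher number from compound 2 to compound 3 (0.70 log units; beyond the scatter). Compound 1 and compound 2 differ in more than one place, so this is the first change shown that can be read on its own. For compound 3 the read-out is a limit and not a number: the limit of > 50000 nM in this assay, at which 1 of the 3 values shown sits.

On these data alone, it remains open which part of the swap matters, the nitrile that leaves or the chain that enters; a benzyl group or a 3-cyanophenethyl group on the same carbonyl carbon would begin to separate the two. Also open, as far as these compounds go, is whether the same swap would give a similar step on the core of compound 1.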